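A few compounds are considered here, and "the series" means these few. Any claim that something is new, unique, unknown or untested is made for them only; others in the source may bear on it.

Compound 1 `Cc1ccccc1Nc1nc(Nc2cccnc2)ncc1Cl`: 41200 nM
Compound 2 `Cc1ccccc1Nc1nc(NC2CC2)ncc1Cl`: > 100000 nM
Compound 3 `Cc1ccccc1Nc1nc(NCc2ccco2)ncc1Cl`: > 100000 nM

In a functional assay on MDA-MB-231 cells (Homo sapiens) for inhibition, read by CCK-8 assay, with a stated time of 48 h (on this read-out lower numbers stand for stronger inhibition of growth and higher numbers for weaker inhibition of growth), compound 1 gives a number. Compound 2 gives only a limit of the assay, (the limit of > 100000 nM in this assay, at which 2 of the 3 values shown sit), so where it truly stands is not known. Compound 4 `Cc1ccccc1Nc1nc(Nc2cc(Cl)ccn2)ncc1Cl` differs from compound 2 in one place: 4-chloropyridin-2-yl in place of cyclopropyl on a nitrogen on an aromatic ring. The step that bears on this is an at least 2.4-fold higher number from compound 1 to compound 2 (0.38 log units; beyond the scatter), where swapping a pyridinyl group for cyclopropyl pushed the number past the limit; an at least 2.4-fold higher number from compound 1 to compound 3 (0.38 log units; beyond the scatter) points the same way for a non-aryl group. Putting an aromatic pyridinyl back is therefore expected to lower the number again, giving a step of about an at least 2.5-fold lower number from compound 2 to compound 4 (0.39 log units; beyond the scatter). Compound 4 is estimated at 40000 nM, between 12000 nM and 120000 nM.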

Compound 4, concentration for 50% growth inhibition: 52400 nM
The estimate for compound 4 lay 1.3-fold (0.12 log units) below the measured number; low and high end bracket the measured number.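

In this assay, 4-chloropyridin-2-yl on this nitrogen gives a reading much like that of the pyridin-3-yl group, with a 1.3-fold higher number from compound 1 to compound 4 (0.10 log units; within the scatter). Against the two non-aromatic groups, the readings are an at least 1.9-fold lower number from compound 2 to compound 4 (0.28 log units; that floor lies within the scatter) and an at least 1.9-fold lower number from compound 3 to compound 4 (0.28 log units; that floor lies within the scatter), so a real gain is suggested but not secured. Compound 2 and compound 3 each give only a limit of the assay, not a number: the limit of > 100000 nM in this assay, at which 2 of the 4 values shown sit.

Going by these compounds, it remains open whether a plain phenyl group, with no ring nitrogen, would serve as well as these pyridinyl groups. On these data alone, it is also open whether a morpholine on this nitrogen would differ from them.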